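Trichlorophenyl replaces methoxyphenyl on the triazole nitrogen

The compounds below may be only part of what the source reports. "The series", "measured", "known", "first", "only" and "open" are said of these compounds alone.

Compound 1 `N#CC1=C(N)Oc2c(c3nc4ccccc4nc3c3ccccc23)C12C(=O)N(Cc1cnnn1-c1cccc(S(N)(=O)=O)c1)c1ccccc12`: 21500 nM in a functional assay on HepG2 cells (Homo sapiens) for antiproliferative activity, read by MTT assay, with a stated time of 48 h; a lower number here means a stronger inhibitor, a higher number a weaker inhibitor
Compound 2 `N#CC1=C(N)Oc2c(c3nc4ccccc4nc3c3ccccc23)C12C(=O)N(Cc1cnnn1-c1cc(Cl)ccc1Cl)c1ccccc12`: > 50000 nM, a limit of this assay, not a number
Compound 3 `COc1ccccc1-n1nncc1CN1C(=O)C2(C(C#N)=C(N)Oc3c(N)cc4nc5ccccc5nc4c32)c2ccccc21`: > 50000 nM, a limit of this assay, not a number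

Of the compounds shown here, three sharing one core have been measured. Compound 1 gives 21500 nM in this assay. Compound 2 reaches only the limit > 50000 nM. Compound 3 likewise reaches only the limit > 50000 nM, so compound 3 stands at the weak end of what has been measured, with no exact number known (the limit of > 50000 nM in this assay, at which 2 of the 3 values shown sit).

Compound 4 `N#CC1=C(N)Oc2c(N)cc3nc4ccccc4nc3c2C12C(=O)N(Cc1cnnn1-c1c(Cl)cc(Cl)cc1Cl)c1ccccc12` differs from compound 3 in one place: 2,4,6-trichlorophenyl in place of 2-methoxyphenyl on an aromatic nitrogen. Among the measured compounds shown here, the one measured step that bears on it is an at least 2.3-fold higher number from compound 1 to compound 2 (0.36 log units; beyond the scatter), where a chlorinated phenyl on the same aromatic nitrogen gave a weaker inhibitor. Nothing measured suggests that a chlorinated phenyl strengthens inhibition here. Compound 4 is therefore expected to remain at or beyond the limit, with an estimated step that the limit leaves unreadable from compound 3 to compound 4. The estimate for compound 4 is 70000 nM, in a range from 40000 nM to 250000 nM.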

Compound 4, half-maximal inhibitory concentration: 37800 nM
Estimate against measurement, compound 4: 1.9-fold (0.27 log units) above; measured number below the stated range.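

In this assay compound 3 gives only > 50000 nM, which is a limit and not a number. The change to 2,4,6-trichlorophenyl gives an at least 1.3-fold lower number from compound 3 to compound 4 (0.12 log units; that floor lies within the scatter), and the true size of this step stays unread because one of its ends is a limit: the limit of > 50000 nM in this assay, at which 2 of the 4 values shown sit A chlorinated phenyl on this aromatic nitrogen therefore need not end at the limit, although compound 2 does, and this floor alone supports no claim of stronger inhibition.

The compounds shown leave open whether a plain phenyl or a pyridyl on this nitrogen would also give a number on the core of compound 3. They also leave open how the 3-sulfamoylphenyl of compound 1 would behave on that core.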